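The source may report more compounds than this note shows. Statements on the series, on what has been measured and on what is new or still open speak of the compounds shown alone.

Measured compounds in this series:

compound 1 `O=C(O)C1CC1c1ccc(NCc2cccc(Oc3ccccc3)c2)cc1` — 74%
compound 2 `O=C(O)CCc1ccc(NCc2ccc(-c3ccccc3)cc2)cc1` — 111%
compound 3 `O=C(O)CCc1ccc(NCc2cccc(Br)c2)cc1` — 120%

All three values come from a functional assay on CHO cells for agonist activity at Free fatty acid receptor 1 (Homo sapiens), read by reporter gene assay; on this read-out higher numbers stand for larger maximal responses and lower numbers for smaller maximal responses. On the numbers alone compound 3 stands at the top of the three, but the gap to compound 2 lies within the scatter of repeated measurements, so the two cannot be told apart on this read-out. Compound 1 is the only one that clearly separates from compound 3, sitting lower by a margin beyond the scatter.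

The next step goes from compound 3 to compound 4 `O=C(O)CCc1ccc(NCc2cccc(F)c2)cc1`, which has not yet been measured in this assay. The change is fluoro in place of bromo on an aromatic carbon. Both substituents are single heavy atoms without donors, acceptors or charge, and no other part of the structure moves. Going by the values given here, no measured pair isolates a change of this kind, so nothing here shows what such a swap does on this read-out.

For compound 4 the expectation is a maximal response near that of compound 3, with a step from compound 3 to compound 4 of a number 8 percentage points lower from compound 3 to compound 4 (within the scatter), that is, none beyond the scatter. Compound 4 is thus estimated at 112%, with a range from 92% to 132%.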

Compound 4, largest response reached (reported as percent of maximum), in percent of the reference or control that the assay uses: 120%
Compound 4: middle estimate off by 8 percentage points, on the low side; the measured number falls inside the stated range.
By their numbers in this assay, from the lowest: compound 1; then compounds 2, 3 and 4 (each within the scatter of the next).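

In this assay, fluoro in place of bromo shows no change at the digits printed from compound 3 to compound 4 (within the scatter) and gives the series its first comparison of compounds that differ in one place. On an aromatic carbon meta to a large group, this read-out therefore does not separate the two halogens, each a single heavy atom with no hydrogen-bond donors or acceptors and no net charge, so the maximal response gives no reason to prefer one over the other on this shared core. Nothing at hand accounts for this outcome.

The comparison covers only two halogens at one place and only the largest response reached, so it leaves open whether the two compounds also match in the concentration needed to reach that response. Also open, going by these compounds, is whether the maximal response holds when this place carries a hydrogen, or a group of a different kind such as methoxy, trifluoromethyl, nitrile or an amine, and whether fluoro gives the same reading when moved to another carbon of the same ring.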